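Hydroxy for carbamoyl on the piperidine side chain

The compounds below may be only part of what the source reports. "The series", "measured", "known", "first", "only" and "open" are said of these compounds alone.

Measured compounds in a functional assay on the whole organism (blood, strain ICR) with Mus musculus as the target, in the glucose tolerance test, with a stated time of 30 min; a lower number here means that less compound is needed, a higher number that more compound is needed for the effect:
- compound 1 `O=S1(=O)Cc2nc(-c3cc(F)c(Cl)cc3F)nc(N3CCC(CO)CC3)c2C1`: 0.3 mg/kg
- compound 2 `NC(=O)C1CCN(c2nc(-c3cc(F)c(Cl)cc3F)nc3c2CS(=O)(=O)C3)CC1`: 3 mg/kg
- compound 3 `NC(=O)CCC1CCN(c2nc(-c3cc(F)c(Cl)cc3F)nc3c2CS(=O)(=O)C3)CC1`: 0.3 mg/kg

Compound 3 stands level with compound 1 at the digits printed, the two together giving the lowest numbers of the three; its furthest neighbour is compound 2, reached by a 10-fold lower number from compound 2 to compound 3 (1.00 log units; beyond the scatter). The other measured steps are a 10-fold higher number from compound 1 to compound 2 (1.00 log units; beyond the scatter) and no change at the digits printed from compound 1 to compound 3 (within the scatter).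

The next compound is compound 4 `O=S1(=O)Cc2nc(-c3cc(F)c(Cl)cc3F)nc(N3CCC(CCO)CC3)c2C1`, which differs from compound 3 by hydroxy in place of carbamoyl on a saturated chain carbon, two bonds along the chain from a saturated ring carbon.

Within the data shown here, two steps bear on this change. The exchange of hydroxymethyl for carbamoyl on the ring carbon gave a 10-fold higher number from compound 1 to compound 2 (1.00 log units; beyond the scatter), whereas carbamoylmethyl entering for hydroxy one bond further out gave no change at the digits printed from compound 1 to compound 3 (within the scatter). The change to compound 4 keeps the chain length of compound 3 and swaps only the terminal group, a swap that left compound 1 and compound 3 level. The hydroxy-terminated chain is therefore expected to behave like that of compound 1, so no change at the digits printed from compound 3 to compound 4 (within the scatter) is expected, with no shift beyond the scatter.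

Compound 4 is thus estimated at 0.3 mg/kg, with a range from 0.1 mg/kg to 1 mg/kg.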

Compound 4, minimum effective dose: 1 mg/kg
Beside the measured number, compound 4's estimate is 3.3-fold (0.52 log units) below it; the measured number falls inside the stated range.
By their numbers in this assay, from the lowest: compounds 1 and 3 (each within the scatter of the next); then compound 4; then compound 2.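

In this assay the end group on this chain is not interchangeable: hydroxy in place of carbamoyl gives a 3.3-fold higher number from compound 3 to compound 4 (0.52 log units; beyond the scatter) and so separates 2-hydroxyethyl from 2-carbamoylethyl, a difference that the level pair of compound 1 and compound 3 did not reveal. Going from hydroxymethyl to 2-hydroxyethyl gives a 3.3-fold higher number from compound 1 to compound 4 (0.52 log units; beyond the scatter) while the carbamoyl-ended pair runs the other way with a 10-fold lower number from compound 2 to compound 3 (1.00 log units; beyond the scatter) so chain length and end group do not act independently across these four compounds. Compound 4 still keeps an advantage over carbamoyl on the saturated ring carbon, with a 3.0-fold lower number from compound 2 to compound 4 (0.48 log units; beyond the scatter) placing it in the middle of the set, and no measurement at hand gives a reason for any of these shifts.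

The compounds shown leave open whether the gain of 2-carbamoylethyl belongs to the carbamoyl group itself or would also appear with a carboxylic acid or an amine at the end of the same chain. They also leave open whether a longer chain, such as 3-hydroxypropyl or 3-carbamoylpropyl, would continue either trend in this assay or reverse it.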